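Swapping a pyridine for a phenoxy group in cyanoazetidine ethers

A few compounds are considered here, and "the series" means these few. Any claim that something is new, unique, unknown or untested is made for them only; others in the source may bear on it.

Compound 3 `N#CN1CC(OCc2ccc(-c3cccnc3)cc2)C1` gives the highest number of the three measured compounds in an assay on isolated protein for inhibition of N-acylethanolamine-hydrolyzing acid amidase (Homo sapiens), read by fluorescence, with a stated time of 90 min (a lower number here means a stronger inhibitor, a higher number a weaker inhibitor), at 12 nM. The other two sit far below it: compound 1 `Cc1ccc(-c2ccc(COC3CN(C#N)C3)cc2)cc1` gives 0.46 nM and compound 2 `N#CN1CC(OCc2ccc(-c3ccc(F)cc3)cc2)C1` gives 0.68 nM. The gaps are a 26-fold higher number from compound 1 to compound 3 (1.42 log units; beyond the scatter) and an 18-fold higher number from compound 2 to compound 3 (1.25 log units; beyond the scatter), in each case a large rise when a carbon-only aromatic ring is replaced by pyridin-3-yl. Between compound 1 and compound 2 the step is a 1.5-fold higher number from compound 1 to compound 2 (0.17 log units; within the scatter).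

Compound 4 `N#CN1CC(OCc2ccc(Oc3ccccc3)cc2)C1` is reached from compound 3 by the change (phenoxy in place of pyridin-3-yl on an aromatic carbon). This reverses the kind of change seen in the two large steps: an aromatic ring containing nitrogen gives way to one of carbon only, though now joined through an oxygen rather than directly. Going by the values given here, no measured compound carries such a phenoxy link, so the effect of the oxygen itself cannot be read from the numbers. On the two large steps alone a drop is expected, and the expected step from compound 3 to compound 4 is an 8.0-fold lower number from compound 3 to compound 4 (0.90 log units; beyond the scatter). Compound 4 is therefore estimated at 1.5 nM in this assay, with a likely range from 0.3 nM to 8 nM.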

Compound 4, half-maximal inhibitory concentration: 1.1 nM
Estimate against measurement, compound 4: 1.4-fold (0.13 log units) above, within the range that was stated.
By their numbers in this assay, from the lowest: compounds 1, 2 and 4 (each within the scatter of the next, the first and the last beyond it); then compound 3.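

In this assay the phenoxy group recovers most of what the pyridin-3-yl group gave up, with an 11-fold lower number from compound 3 to compound 4 (1.04 log units; beyond the scatter) as the result. Compounds 1, 2 and 4 all carry a ring of carbon only at this position and compound 3 alone carries a ring with nitrogen, so the carbon-only ring keeps the number low here whether it is attached directly or through an oxygen. The link does not erase every difference: the comparison with the 4-fluorophenyl group gives a 1.6-fold higher number from compound 2 to compound 4 (0.21 log units; within the scatter) and so shows no real separation, while the comparison with the 4-methylphenyl group gives a 2.4-fold higher number from compound 1 to compound 4 (0.38 log units; beyond the scatter) and leaves a modest gap that lies beyond the scatter.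

Nothing measured here bears on why the ring with nitrogen gives the higher number. Also open, on these data alone, is how the number would respond to a 4-fluorophenoxy or 4-methylphenoxy group, to a pyridinyloxy group that puts nitrogen back into the oxygen-linked ring, or to a benzyl group that has a carbon link in place of the oxygen.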